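The source may report more compounds than this note shows. Statements on the series, on what has been measured and on what is new or still open speak of the compounds shown alone.

Compound 3 `COc1cccc(-c2nc3c(-c4cccc(Cl)c4)n[nH]c3c(=O)n2NC(=O)c2ccccc2)c1` gives 81.9% in a functional assay on SK-MEL-2 cells (Homo sapiens) for cytotoxicity, read by sulforhodamine B assay, with a stated time of 2 days, tested at 100 uM (a lower number here means less inhibition, a higher number more inhibition at the concentration tested (going by the name of the read-out)), the highest of the three numbers measured. Its nearest neighbour is compound 1 `COc1cccc(-c2nc3c(-c4ccc(Cl)cc4)n[nH]c3c(=O)n2NC(=O)c2ccncc2)c1`, which in this assay gives 39.6%, a gap beyond the scatter. Compound 2 `CCCc1n[nH]c2c(=O)n(NC(=O)c3ccccc3)c(-c3cccc(OC)c3)nc12` in this assay gives 16.7%, the lowest of the set. Among the compounds with values here, the one single-point step that has been measured runs a number 65.2 percentage points higher from compound 2 to compound 3 (beyond the scatter), a large rise.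

The step now followed leads from compound 3 to compound 4 `COc1cccc(-c2nc3c(-c4ccc(Cl)cc4)n[nH]c3c(=O)n2NC(=O)c2ccccc2)c1`. The change is 4-chlorophenyl in place of 3-chlorophenyl on an aromatic carbon. Within the data shown here, no measured step isolates this swap: the pair compound 1 and compound 3 differ in the chlorophenyl and in the amide at the same time, so their values can only be read together. Compound 1 does carry the 4-chlorophenyl that compound 4 will carry, and its value sits well under that of compound 3, while the measured step from compound 2 to compound 3 concerns a different exchange and bears on this one only loosely.

Compound 4 is therefore expected to give a lower number than compound 3 in this assay. The step expected in this assay is a number 19.9 percentage points lower from compound 3 to compound 4 (beyond the scatter). The estimate for compound 4 in this assay is 62%, with a range from 38% to 86%.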

Compound 4, a percentage reported as inhibition, at one concentration (the size of the read-out at that concentration, not a potency): 84.9%
Compound 4: the middle estimate sits 22.9 percentage points below what was measured, and the stated range covers the measured number.
By their numbers in this assay, from the lowest: compound 2; then compound 1; then compounds 3 and 4 (each within the scatter of the next).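

In this assay, the exchange of 3-chlorophenyl for 4-chlorophenyl on this aromatic carbon gives a number 3 percentage points higher from compound 3 to compound 4 (within the scatter), so the two chlorophenyl groups cannot be told apart here, and the large a number 68.2 percentage points higher from compound 2 to compound 4 (beyond the scatter) shows that either one reads far from propyl at this place. Compound 4 also isolates the change on the carbonyl carbon that could not be separated before: with 4-chlorophenyl held constant, phenyl in place of pyridin-4-yl gives a number 45.3 percentage points higher from compound 1 to compound 4 (beyond the scatter), which ties the low number of compound 1 to its pyridin-4-yl and not to its 4-chlorophenyl. Nothing available bears on why either exchange reads as it does.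

The compounds shown leave open how an unsubstituted phenyl or a 4-methoxyphenyl would read on this aromatic carbon, and how a pyridin-3-yl or a 4-aminophenyl would read on the carbonyl carbon. Since each number comes from a single concentration, they also leave open whether compound 3 and compound 4 would still read alike at other concentrations.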